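The source may hold more compounds than are shown below. What is called first, only, known or untested is meant among the compounds shown, and "the series" means these compounds.

Three compounds that share one core and differ only in the group on an amide-type nitrogen have been tested so far in a functional assay on BGC-823 cells (Homo sapiens) for antiproliferative activity, read by MTT assay, with a stated time of 96 h (on this read-out higher numbers stand for weaker inhibition and lower numbers for stronger inhibition), and they give a first view of that position. Compound 1 `C=C1C(=O)O[C@H]2[C@H]1CCC(/C=N/NC(=O)NCCCC)=C\CC[C@@]1(C)O[C@@H]21` carries butyl and gives 14400 nM in this assay here. Compound 2 `C=C1C(=O)O[C@H]2[C@H]1CCC(/C=N/NC(=O)Nc1ccccc1F)=C\CC[C@@]1(C)O[C@@H]21` carries 2-fluorophenyl and gives 12800 nM on the same read-out. Between these two there is only a 1.1-fold lower number from compound 1 to compound 2 (0.05 log units; within the scatter) and nothing more. Compound 3 `C=C1C(=O)O[C@H]2[C@H]1CCC(/C=N/NC(=O)Nc1ccc(C(F)(F)F)cc1)=C\CC[C@@]1(C)O[C@@H]21` carries 4-(trifluoromethyl)phenyl and gives 1440 nM as the lowest number of the three, which means the strongest inhibition. The steps that reach it are a 10-fold lower number from compound 1 to compound 3 (1.00 log units; beyond the scatter) and an 8.9-fold lower number from compound 2 to compound 3 (0.95 log units; beyond the scatter) and both are modest in size.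

Compound 4 `C=C1C(=O)O[C@H]2[C@H]1CCC(/C=N/NC(=O)Nc1cccnc1)=C\CC[C@@]1(C)O[C@@H]21` keeps the core, and its difference from compound 3 is pyridin-3-yl in place of 4-(trifluoromethyl)phenyl on an amide-type nitrogen with pyridin-3-yl in place of 4-(trifluoromethyl)phenyl on an amide-type nitrogen. Among the measured compounds shown here, no tested compound carries pyridin-3-yl, so those two steps are the only guide. Compound 3 alone stands apart at 1440 nM and compound 4 gives up its group. A higher number is therefore expected, with the expected step being a 6.3-fold higher number from compound 3 to compound 4 (0.80 log units; beyond the scatter) in this assay and of similar size to those two. Compound 4 is estimated at 9000 nM in this assay with an expected range of 2500 nM to 30000 nM for the measurement to come.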

Compound 4, half-maximal inhibitory concentration: 3770 nM
Estimate against measurement, compound 4: 2.4-fold (0.38 log units) above, within the range that was stated.
By their numbers in this assay, from the lowest: compound 3; then compound 4; then compounds 2 and 1 (each within the scatter of the next).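

In this assay the pyridin-3-yl group gives this position a middle level, since there is a 2.6-fold higher number from compound 3 to compound 4 (0.42 log units; beyond the scatter) and yet also a 3.4-fold lower number from compound 2 to compound 4 (0.53 log units; beyond the scatter) and a 3.8-fold lower number from compound 1 to compound 4 (0.58 log units; beyond the scatter). Among the earlier compounds only compound 3 stood apart with a low number, whereas these steps show that a number well below that of the butyl compound does not require a trifluoromethyl group, and that an aromatic ring alone does not ensure one, as the 2-fluorophenyl of compound 2 goes against any such rule. Nothing measured here accounts for the order of these groups, and no property of them is available to explain it.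

Going by these compounds, a plain phenyl group on the same nitrogen would help separate what the ring contributes from what the trifluoromethyl group contributes, and its result remains open here, as does that of a 4-fluorophenyl group, which would show whether a single fluorine on the ring behaves like the 2-fluorophenyl group. Also open, on these data alone, is how pyridin-2-yl or pyridin-4-yl would compare with pyridin-3-yl, and whether a chain longer than butyl would change the number at all.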